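Working notes: from compound 2 to compound 3

The source may report more compounds than this note shows. Statements on the series, on what has been measured and on what is new or still open speak of the compounds shown alone.

Measured in a functional assay on LOX IMVI cells (Homo sapiens) for inhibition, with a stated time of 48 h; on this read-out higher numbers stand for weaker inhibition of growth and lower numbers for stronger inhibition of growth:
- compound 1 `COc1c(C(=O)/C=C/c2ccc(Cl)cc2)c(O)c(Br)c2occc12` gives 2200 nM
- compound 2 `C=CCc1c(O)c(C(=O)/C=C/c2ccccc2)c(OC)c2ccoc12` gives 1560 nM

Compound 2 stands within the scatter of compound 1, so these two numbers set no order. Going by the values given here, compound 3 `C=CCc1c(O)c(C(=O)/C=C/c2ccc(Cl)cc2)c(OC)c2ccoc12` follows from compound 2 with chloro in place of hydrogen on an aromatic carbon as the only change. Among the compounds with values here, no measured pair shows this change alone. Only a small step is expected in this assay because compound 1 with its 4-chlorophenyl gives 2200 nM and so stays close to compound 2. The estimated step of a 1.1-fold higher number from compound 2 to compound 3 (0.04 log units; within the scatter) lies within the scatter. The expected value for compound 3 is 1700 nM within an estimated range from 750 nM to 3800 nM in this read-out.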

Compound 3, concentration for 50% growth inhibition: 1630 nM
For compound 3 the middle estimate is 1.0-fold (0.02 log units) above the measured one, and the stated range covers the measured number.
By their numbers in this assay, from the lowest: compounds 2, 3 and 1 (each within the scatter of the next).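

In this assay the change from phenyl to 4-chlorophenyl now has a direct reading: chloro in place of hydrogen, para to a large group, gives a 1.0-fold higher number from compound 2 to compound 3 (0.02 log units; within the scatter) and leaves the read-out unmoved within the scatter. Allyl in place of bromo on an aromatic carbon also stays within the scatter, with a 1.3-fold lower number from compound 1 to compound 3 (0.13 log units; within the scatter) as its step. Nothing measured on hand explains either step. Still open, from the compounds shown here alone, is whether an amine or a carboxylic acid in place of chloro moves the number, and whether a longer chain in place of allyl does.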